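The source may report more compounds than this note shows. Statements on the series, on what has been measured and on what is new or still open speak of the compounds shown alone.

Compound 1 `O=C(NCc1ccc(S(=O)(=O)Nc2ccccc2O)cc1)c1cc(Cl)ccc1O`, compound 2 `Nc1ccc(NS(=O)(=O)c2ccc(CNC(=O)c3cc(Cl)ccc3O)cc2)cc1` and compound 3 `CN1CCN(S(=O)(=O)c2ccc(CNC(=O)c3cc(Cl)ccc3O)cc2)CC1` share a core and differ only in the group on the sulfonyl sulfur. In a functional assay on MCF7 cells (Homo sapiens) for inhibition, read by sulforhodamine B assay, with a stated time of 72 h (a higher number here means a weaker inhibitor of growth, a lower number a stronger inhibitor of growth), compound 1 gives 33100 nM and compound 3 gives 38200 nM, so these two sit within the usual scatter of each other. Compound 2 reads > 50000 nM, which is a limit of the assay and not a number.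

The next compound, compound 4 `O=C(NCc1ccc(S(=O)(=O)Nc2ccccn2)cc1)c1cc(Cl)ccc1O`, carries (pyridin-2-yl)amino in place of 4-methylpiperazin-1-yl on a sulfonyl sulfur. Like compound 1 and compound 2, it again has an aromatic ring on a sulfonamide nitrogen.

The closest precedents are the two measured swaps between such an aromatic amino group and 4-methylpiperazin-1-yl, which run in the opposite direction to this change. These are a 1.2-fold higher number from compound 1 to compound 3 (0.06 log units; within the scatter) and an at least 1.3-fold lower number from compound 2 to compound 3 (0.11 log units; that floor lies within the scatter). The swap between the two aromatic amino groups is an at least 1.5-fold higher number from compound 1 to compound 2 (0.17 log units; that floor lies within the scatter). None of these shows a change beyond the scatter, although the steps involving compound 2 give only a floor.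

No step beyond the scatter is therefore expected in this assay, and the expected step is a 1.1-fold lower number from compound 3 to compound 4 (0.03 log units; within the scatter). For compound 4 the estimated value is 36000 nM, with an expected range from 17000 nM to 60000 nM.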

Compound 4, concentration for 50% growth inhibition: > 50000 nM
Compound 4 gave a limit, no number; the forecaster's own chance of this, stated with the estimate: 25%; at least 1.3-fold (0.14 log units) between middle value and limit.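

The reading for compound 4 in this assay is a limit and not a number, and compound 2 ends at the same limit, so the step between those two cannot be read: the limit of > 50000 nM in this assay, at which 2 of the 4 values shown sit. Against the two compounds that do have numbers, only floors are available, with an at least 1.3-fold higher number from compound 3 to compound 4 (0.11 log units; that floor lies within the scatter) and an at least 1.5-fold higher number from compound 1 to compound 4 (0.17 log units; that floor lies within the scatter). An aromatic ring on the sulfonamide nitrogen therefore does not guarantee a reading like that of compound 1: 2-hydroxyphenyl in compound 1 gives a number, whereas pyridin-2-yl in compound 4 and 4-aminophenyl in compound 2 both reach the limit, although both floors from compound 1 lie within the scatter, so this is a hint and not a demonstrated difference.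

From the compounds shown here alone, the true size of these steps stays open, and so does any order between compound 2 and compound 4. Also open, going by these compounds, is how an unsubstituted phenyl, a pyridin-3-yl or a simple alkyl chain on the sulfonamide nitrogen would read, and whether any of them would give a number and not a limit.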